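Replacing the trifluoromethoxyphenyl group with a methylpyrazole

The source may report more compounds than this note shows. Statements on the series, on what has been measured and on what is new or still open speak of the compounds shown alone.

Compound 1 `Cc1cnc(Nc2ccc(C(=O)Nc3c(C)cccc3C)cc2)nc1-c1cccc(OC(F)(F)F)c1` carries a 3-(trifluoromethoxy)phenyl group on the shared core. Among the compounds with values here, in an assay on NIH3T3 cells for inhibition of Sonic hedgehog protein (Mus musculus), read by a luciferase reporter, with a stated time of 48 h (on this read-out higher numbers stand for weaker inhibition and lower numbers for stronger inhibition), compound 1 gives 1.2 nM, the lowest of the two numbers measured so far. Its nearest neighbour is compound 2 `Cc1cnc(Nc2ccc(C(=O)Nc3c(C)cccc3C)cc2)nc1-c1ccc(C#N)cc1`, which in this assay gives 2.8 nM. Within the data shown here, the single measured step, a 2.3-fold higher number from compound 1 to compound 2 (0.37 log units; beyond the scatter), exchanges one six-membered carbon ring for another bearing a different group and weakens inhibition modestly.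

Compound 3 `Cc1cnc(Nc2ccc(C(=O)Nc3c(C)cccc3C)cc2)nc1-c1cnn(C)c1` has not yet been measured. It differs from compound 1 in one place: 1-methyl-1H-pyrazol-4-yl in place of 3-(trifluoromethoxy)phenyl on an aromatic carbon. The new group sits on an aromatic carbon of a six-membered aromatic ring with two nitrogen, next to the ring nitrogen, ortho to a methyl group and meta to a large group. Among the measured compounds shown here, the step from compound 1 to compound 2 is the only guide, and it concerns a different exchange at the same position; it showed that altering this group costs a little potency. Compound 3 is therefore expected to give about 4 nM, with a likely range from 1.2 nM to 15 nM. That expected change, a 3.3-fold higher number from compound 1 to compound 3 (0.52 log units; beyond the scatter), would be somewhat larger than the measured one.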

Compound 3, half-maximal inhibitory concentration: 10.6 nM
Compound 3: the middle estimate sits 2.7-fold (0.42 log units) below what was measured, and the stated range covers the measured number.
By their numbers in this assay, from the lowest: compound 1; then compound 2; then compound 3.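

In this assay, moving to the smaller 1-methyl-1H-pyrazol-4-yl group gives an 8.8-fold higher number from compound 1 to compound 3 (0.95 log units; beyond the scatter), so a six-membered carbon ring at this place is not needed for inhibition in the nanomolar range, although it is the better of the two ring types tested here. The second comparison, a 3.8-fold higher number from compound 2 to compound 3 (0.58 log units; beyond the scatter), shows that the five-membered ring also falls behind the 4-cyanophenyl group, so both groups with a six-membered carbon ring give lower numbers than the pyrazole, and none of the three compounds goes against this. Nothing available explains why the number rises on this change.

The compounds shown leave open whether the higher number of compound 3 goes with the smaller ring, with its two nitrogen atoms or with the methyl group on it. An unsubstituted phenyl ring, a pyridine ring or a pyrazole carrying an ethyl group instead of the methyl group at this place on the shared core would help to separate these changes.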